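The source may report more compounds than this note shows. Statements on the series, on what has been measured and on what is new or still open speak of the compounds shown alone.

Working notes on the series.

Compound 1 `CC(C)n1cnc2c(Nc3cccc(Cl)c3)nc(NCOCc3ccc(C(=O)Nc4ccccc4N)cc3)nc21` gives 43.2% in a functional assay on NCI-H460 cells (Homo sapiens) for antiproliferative activity, read by CCK-8 assay, with a stated time of 72 h, tested at 8 uM; on this read-out lower numbers stand for a weaker effect and higher numbers for a stronger effect at the one concentration tested. Among the three measured numbers it stands second highest: compound 3 `Nc1ccccc1NC(=O)/C=C/c1ccc(Cn2cnc3c(NCc4ccccc4)nc(Cl)nc32)cc1` gives 49.1%, which lies within the scatter of compound 1, while compound 2 `Nc1ccccc1NC(=O)/C=C/c1ccc(Cn2cnc3c(Nc4cccc(Cl)c4)nc(Cl)nc32)cc1` gives 29.4%, a number beyond the scatter below compound 1. Among the measured compounds shown here, the only single-place step recorded is a number 19.7 percentage points higher from compound 2 to compound 3 (beyond the scatter).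

Compound 4 `CC(C)n1cnc2c(Nc3ccccc3)nc(NCOCc3ccc(C(=O)Nc4ccccc4N)cc3)nc21` differs from compound 1 by hydrogen in place of chloro on an aromatic carbon. For the measured compounds named here, no measured step removes chloro alone; the step from compound 2 to compound 3 swaps the whole group and does not bear directly on this change. A step within the scatter is therefore expected in this assay, in no particular direction. For compound 4 the estimate is 40%, with a range from 25% to 55%, an expected step of a number 3.2 percentage points lower from compound 1 to compound 4 (within the scatter).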

Compound 4, a percentage reported as inhibition, at one concentration (the size of the read-out at that concentration, not a potency): 34.3%
Estimate against measurement, compound 4: 5.7 percentage points above; measured number inside the range.
By their numbers in this assay, from the lowest: compounds 2, 4, 1 and 3 (each within the scatter of the next, the first and the last beyond it).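

Among the compounds shown here, the step of a number 8.9 percentage points lower from compound 1 to compound 4 (within the scatter) in this assay is the first reading of the chloro alone, since the step of a number 19.7 percentage points higher from compound 2 to compound 3 (beyond the scatter) swapped the whole group. At this place on the ring, then, hydrogen in place of chloro leaves the read-out within the scatter for this pair, and a single pair sets no trend. No measurement at hand gives a reason for this step. From the compounds shown here alone, whether a methoxy, a fluoro or an amine at this place would move the number beyond the scatter stays open, as does whether removing the chloro from compound 2 would give a similar step.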